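The source may report more compounds than this note shows. Statements on the series, on what has been measured and on what is new or still open speak of the compounds shown alone.

Measured so far in a functional assay on MCF7 cells (Homo sapiens) for cytotoxicity, read by MTT assay, with a stated time of 72 h; a higher number here means a weaker inhibitor of growth, a lower number a stronger inhibitor of growth:

Compound 1, `CCCCC[Se]c1nc(N)c2ccccc2n1`, gives 28600 nM.
Compound 2, `CCCCC[Se]c1nc(NCc2ccccc2)c2ccccc2n1`, gives 50 nM.

Compound 2 stands at the lower of the two numbers, and the gap to compound 1 is large: a 570-fold lower number from compound 1 to compound 2 (2.76 log units; beyond the scatter). That single step is the only measured one, and it concerns a different part of the molecule than the change now in question.

Compound 3, `CCCCC[Se]c1nc(NCc2ccc(SC)cc2)c2ccccc2n1`, differs from compound 2 in one place: methylsulfanyl in place of hydrogen on an aromatic carbon. The new group sits para to a large group on the benzyl ring. Going by the values given here, no measured step touches this ring, so there is nothing here that points to a shift in either direction, and the change is expected to stay within the scatter of this assay .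

Compound 3 is therefore expected to come out near compound 2, with an estimated step of a 1.1-fold lower number from compound 2 to compound 3 (0.05 log units; within the scatter), giving an expected value of 45 nM and a range from 15 nM to 150 nM.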

Compound 3, concentration for 50% growth inhibition: 34700 nM
Estimate against measurement, compound 3: 770-fold (2.89 log units) below; the measured number lies above the stated range.
By their numbers in this assay, from the lowest: compound 2; then compounds 1 and 3 (each within the scatter of the next).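

The benzyl ring is not a place where a small addition passes unnoticed: in this assay, methylsulfanyl in place of hydrogen on this ring gives a large loss of growth inhibition (a 690-fold higher number from compound 2 to compound 3 (2.84 log units; beyond the scatter)). The entering group has only 2 heavy atoms, yet this step is large, just as the step that brought in the benzyl group was large, so the benzyl ring matters to this read-out as well as the nitrogen that carries it. Nothing measured here explains the loss.

From the compounds shown here alone, whether the loss belongs to methylsulfanyl itself or would follow any group at this place remains open; a fluorine atom, a methoxy group or a carboxylic acid there would begin to separate the two. Also open, going by these compounds, is how methylsulfanyl would behave at another carbon of the ring.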